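Ester Tail Swap in an Angiotensin II Type-2 Receptor Ligand

The source may report more compounds than this note shows. Statements on the series, on what has been measured and on what is new or still open speak of the compounds shown alone.

Compound 1 `CCCc1nc(CC)c(C(=O)OCCC[S+]([O-])c2ccccc2)n1Cc1ccc(-c2ccccc2S(=O)(=O)NC(=O)OCCC(C)C)cc1F` was tested in an assay on isolated protein for binding affinity to Type-2 angiotensin II receptor (Homo sapiens) (a lower number here means a stronger inhibitor, a higher number a weaker inhibitor), where compound 1 gives 1 nM. For the measured compounds named here, only one other compound has been measured alongside it: compound 2 `CCCCN(CCCC)C(=O)CCCOC(=O)c1c(CC)nc(CCC)n1Cc1ccc(-c2ccccc2-c2nn[nH]n2)cc1`, which in this assay gives 500 nM. Compound 1 thus holds the lowest of the two numbers, and the gap to compound 2 lies well beyond the scatter of repeated measurements. Going by the values given here, the two compounds differ in several places at once, so no single step can be drawn between them.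

Compound 3 `CCCc1nc(CC)c(C(=O)OCCCCOc2ccccc2)n1Cc1ccc(-c2ccccc2S(=O)(=O)NC(=O)OCCC(C)C)cc1F` has not yet been measured. It differs from compound 1 in one place: a group of 8 heavy atoms (7 carbon, 1 oxygen; one six-membered aromatic ring of carbon only) in place of a group of 8 heavy atoms (6 carbon, 1 oxygen, 1 sulfur; one six-membered aromatic ring of carbon only), on a saturated chain carbon, three bonds along the chain from an oxygen next to a carbonyl group. The change sits on the ester tail, far from the shared core of compound 1, and the group that enters matches the group that leaves in size and in the count of acceptors. Among the compounds with values here, no measured pair in this set isolates such a change, so the size of the step is uncertain. Compound 3 is expected to show a step of a 2.0-fold higher number from compound 1 to compound 3 (0.30 log units; within the scatter), that is, a change at most slightly beyond the scatter toward a weaker number. Compound 3 is therefore estimated at 2 nM in this assay, with a range from 0.5 nM to 10 nM.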

Compound 3, half-maximal inhibitory concentration: 2 nM
Compound 3: middle estimate and measured number agree at the digits printed; measured number inside the range.
By their numbers in this assay, from the lowest: compounds 1 and 3 (each within the scatter of the next); then compound 2.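

For the compounds shown here, the swap of the tail group for phenoxymethyl, on a saturated chain carbon, three bonds along the chain from an oxygen next to a carbonyl group, gives the first one-place comparison here: in this assay it amounts to a 2.0-fold higher number from compound 1 to compound 3 (0.30 log units; within the scatter), so the two compounds cannot be told apart. This shows that, in this pair, the sulfur of the group that leaves is not needed for a number in this low range, as a group of 8 heavy atoms with carbon and oxygen only serves equally well in this assay, with the same six-membered aromatic ring and the same count of hydrogen-bond acceptors. No measurement in hand offers an explanation for this outcome.

The compounds shown leave open how far this tolerance extends, for instance whether an amine or a carboxylic acid at the end of the tail, or a longer chain ahead of the phenoxymethyl group, would hold the number near that of compound 1. They also leave open how much of the higher number of compound 2 belongs to its ester tail, as that compound differs from compound 1 in several places at once.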